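Swapping 2-methoxyphenyl for 4-hydroxyphenyl in compound 1

A few compounds are considered here, and "the series" means these few. Any claim that something is new, unique, unknown or untested is made for them only; others in the source may bear on it.

Measured in a functional assay on DU-145 cells (Homo sapiens) for inhibition, read by trypan blue exclusion, with a stated time of 96 h; a lower number here means a stronger inhibitor of growth, a higher number a weaker inhibitor of growth:
- compound 1 `COc1ccccc1/C=C(\C(=O)c1ccc(Cl)cc1)S(=O)(=O)Cc1ccc(Cl)c(Cl)c1` gives 1000 nM
- compound 2 `COc1ccccc1/C=C(\C(=O)c1ccc(Cl)cc1)S(=O)(=O)Cc1ccc(Cl)cc1` gives 25000 nM
- compound 3 `COc1ccccc1/C=C(\C(=O)c1ccc(Cl)cc1)S(=O)(=O)c1ccc(Br)cc1` gives 10000 nM

Compound 1 has the lowest number of these three in this assay and so stands as the strongest inhibitor of growth among them. The closest of the others lies at a 10-fold higher number from compound 1 to compound 3 (1.00 log units; beyond the scatter) and the furthest at a 25-fold higher number from compound 1 to compound 2 (1.40 log units; beyond the scatter) on the scale of this series. Compound 4 `O=C(/C(=C\c1ccc(O)cc1)S(=O)(=O)Cc1ccc(Cl)c(Cl)c1)c1ccc(Cl)cc1` keeps the rest of compound 1 and differs by 4-hydroxyphenyl in place of 2-methoxyphenyl on a double-bonded chain carbon bound to a double-bonded chain carbon in the structure. For the measured compounds named here, none of the measured steps touches that place. Going by the values given here, all of them alter the group on the sulfonyl sulfur, including the smaller 2.5-fold lower number from compound 2 to compound 3 (0.40 log units; beyond the scatter) in the same series, so they show only that single changes here can move the number widely. With compound 1 already lowest, a modest rise is expected, though its direction is not firmly fixed by these data. The expected change is a 3.0-fold higher number from compound 1 to compound 4 (0.48 log units; beyond the scatter) as an estimate. The estimate for compound 4 is 3000 nM as the expected value, with 600 nM to 15000 nM as its expected range.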

Compound 4, concentration for 50% growth inhibition: 10000 nM
Compound 4: the middle estimate sits 3.3-fold (0.52 log units) below what was measured; the measured number falls inside the stated range.
By their numbers in this assay, from the lowest: compound 1; then compounds 3 and 4 (each within the scatter of the next); then compound 2.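

In this assay, for the compounds shown here, the swap gives a 10-fold higher number from compound 1 to compound 4 (1.00 log units; beyond the scatter), so this place on a double-bonded chain carbon bound to a double-bonded chain carbon also affects the number, whereas the earlier steps all altered the group on the sulfonyl sulfur or its chloro substitution. The swap replaces the methoxy group with a hydroxy group that adds a hydrogen-bond donor, and the substituent number on the phenyl ring also changes, so this single step cannot separate the two changes. No measurement given here accounts for the rise.

Going by these compounds, what 4-methoxyphenyl or 2-hydroxyphenyl would give at this place remains open, and so does which part of the swap carries the step. On these data alone, it is also open how a 4-aminophenyl group would read here, or whether the step would persist with the 4-chlorobenzyl group of compound 2.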